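This account rests on a few compounds, and the source may have more. Where it says the series, first, only, none or still open, it means among the compounds named here.

Measured so far:
compound 1, `Cc1cccc(C(=O)N(C(=S)OCCN2C(=O)c3ccccc3C2=O)c2ccc(Cl)cc2)c1`: 58000 nM
compound 2, `Cc1ccc(N(C(=O)c2cccc(Cl)c2Cl)C(=S)OCCN2C(=O)c3ccccc3C2=O)cc1`: 35000 nM

Both compounds were tested in an ADME assay on MT4 cells (Homo sapiens) for cytotoxicity, read by MTT assay; on this read-out lower numbers stand for higher toxicity in this test and higher numbers for lower toxicity in this test. Compound 1 carries the larger of the two numbers, but its gap to compound 2 lies within the scatter of repeated measurements, so no real difference between them can be claimed. The unmeasured compound 3, `O=C1c2ccccc2C(=O)N1CCOC(=S)N(C(=O)c1cc2ccccc2s1)c1ccc(Cl)cc1`, keeps the shared core of compound 1 and changes one group on the carbonyl carbon: 1-benzothiophen-2-yl in place of 3-methylphenyl on a carbonyl carbon. Within the data shown here, no pair of measured compounds differs in exactly this way, so nothing in the data tells how such an exchange moves the read-out. Among the measured compounds shown here, with only two measured compounds, both close to each other, the plain expectation is a number near compound 1 and no step beyond the scatter. Compound 3 is estimated at 45000 nM, with a range from 15000 nM to 130000 nM. The step of a 1.3-fold lower number from compound 1 to compound 3 (0.11 log units; within the scatter) that this estimate implies is expected to stay within the scatter.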

Compound 3, half-maximal cytotoxic concentration: 56000 nM
For compound 3 the middle estimate is 1.2-fold (0.09 log units) below the measured one; low and high end bracket the measured number.
By their numbers in this assay, from the lowest: compounds 2, 3 and 1 (each within the scatter of the next).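

On the carbonyl carbon, 1-benzothiophen-2-yl in place of 3-methylphenyl gives a 1.0-fold lower number from compound 1 to compound 3 (0.02 log units; within the scatter) in this assay, so this test cannot tell the two compounds apart. This single exchange shows what compounds 1 and 2 alone could not: at this place, a group of 9 heavy atoms, with a five-membered aromatic ring holding sulfur as well as a six-membered aromatic ring, gives a number within the scatter of the 7-atom 3-methylphenyl group. No measurement at hand explains this result.

On these data alone, whether the read-out would stay the same with an amine or a carboxylic acid at this place remains open, since every group here is aromatic. One pair also cannot show whether the same exchange would behave alike on a core other than that of compound 1.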